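Cytotoxicity notes: bromophenyl isomer change in the indole-piperazine series

The compounds below may be only part of what the source reports. "The series", "measured", "known", "first", "only" and "open" are said of these compounds alone.

Measured compounds:
compound 1 `O=C(CN1CCN(C(=O)c2ccc(Br)cc2)CC1)N1CCN(CCCc2c[nH]c3ccccc23)CC1` — 71900 nM
compound 2 `O=C(CN1CCN(C(=O)c2ccc(Br)cc2)CC1)N1CCN(CCCc2c[nH]c3ccc(F)cc23)CC1` — 60500 nM

In an ADME assay on HEK293 cells (Homo sapiens) for cytotoxicity, read by MTT assay, with a stated time of 72 h (a higher number here means a weaker inhibitor, a lower number a stronger inhibitor), compound 1 gives 71900 nM, and in this assay compound 2 gives 60500 nM. Among the compounds with values here, the only measured step, a 1.2-fold lower number from compound 1 to compound 2 (0.07 log units; within the scatter), lies within the scatter, so the two compounds are not separable on these numbers; compound 2 simply has the lower of the two figures.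

Compound 3 `O=C(CN1CCN(C(=O)c2ccccc2Br)CC1)N1CCN(CCCc2c[nH]c3ccc(F)cc23)CC1` is not yet measured. Its change from compound 2 is 2-bromophenyl in place of 4-bromophenyl on a carbonyl carbon. Within the data shown here, no measured step touches the (4-bromophenyl)carbonyl part, so there is nothing here to anchor a shift in either direction; the one step known, that of compound 1 to compound 2, concerns a different part of the shared core and was itself within the scatter.

The expectation is therefore no step beyond the scatter, a 1.0-fold lower number from compound 2 to compound 3 (0.00 log units; within the scatter). Compound 3 is estimated at 60000 nM in this assay, with a range from 25000 nM to 150000 nM.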

Compound 3, half-maximal inhibitory concentration: 77100 nM
Compound 3: middle estimate off by 1.3-fold (0.11 log units), on the low side; low and high end bracket the measured number.
By their numbers in this assay, from the lowest: compounds 2, 1 and 3 (each within the scatter of the next).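

For the (4-bromophenyl)carbonyl part of the series, the change to (2-bromophenyl)carbonyl now gives a measured step in this assay and it reads a 1.3-fold higher number from compound 2 to compound 3 (0.11 log units; within the scatter) and so does not separate the two isomers. The earlier compounds shown here said nothing about this part, and the bromine can now be placed at either of these two ring positions with the cytotoxicity figure staying inside the scatter of compound 2. Nothing measured here bears on the reason for this outcome.

One isomer pair on a single indole background leaves open whether the same holds without the fluoro group on the shared core. It also leaves open whether a carboxylic acid or an amine in place of the bromine on that phenyl ring would give a step beyond the scatter.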